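From Compound 2 to Compound 4: Pyridin-4-yl Replaces 4-Chlorophenyl

This account rests on a few compounds, and the source may have more. Where it says the series, first, only, none or still open, it means among the compounds named here.

Three measured compounds share one core. Compound 1 `O=C(O)Cc1sc(COc2ccc(Cl)cc2)nc1-c1ccc(Cl)cc1` gives 370 nM in an in vitro functional assay on HEK285-7 cells for antagonist activity at prostaglandin D2 receptor 2 (Homo sapiens), read by BRET and beta-arrestin recruitment; on this read-out higher numbers stand for weaker inhibition and lower numbers for stronger inhibition. Compound 2 `O=C(O)Cc1sc(C(c2ccc(F)cc2)c2ccc(F)cc2)nc1-c1ccc(Cl)cc1` gives 180 nM, and compound 3 `COc1ccc(C(c2ccccn2)c2nc(-c3ccc(Cl)cc3)c(CC(=O)O)s2)cc1` gives 310 nM. Compound 2 holds the lowest of the three numbers; its gap to compound 3 falls within the usual scatter, whereas its gap to compound 1 lies beyond it. Compound 4 `O=C(O)Cc1sc(C(c2ccc(F)cc2)c2ccc(F)cc2)nc1-c1ccncc1` differs from compound 2 in a single place: pyridin-4-yl in place of 4-chlorophenyl on an aromatic carbon. Among the measured compounds shown here, no measured pair here shows this same change, so no precedent exists for it. A modest weakening is expected, a 3.1-fold higher number from compound 2 to compound 4 (0.49 log units; beyond the scatter), larger than the scatter. For compound 4 the estimated value is 550 nM, with an expected range from 200 nM to 1600 nM.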

Compound 4, half-maximal inhibitory concentration: 40 nM
Estimate against measurement, compound 4: 14-fold (1.14 log units) above; measured number outside the range, below it.
By their numbers in this assay, from the lowest: compound 4; then compounds 2, 3 and 1 (each within the scatter of the next, the first and the last beyond it).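

In this assay, pyridin-4-yl in place of 4-chlorophenyl, on the aromatic carbon next to the ring nitrogen, gives a 4.5-fold lower number from compound 2 to compound 4 (0.65 log units; beyond the scatter). Among the compounds shown here, compounds 1, 2 and 3 all carry 4-chlorophenyl here, so only this step shows that the position responds to change and that a ring with a nitrogen and no chlorine is accepted. Nothing available explains the size of this step.

From the compounds shown here alone, whether plain phenyl or pyridin-3-yl would give a similar step remains open. So does whether the same change would carry over to the other groups of compound 1 and compound 3.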